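Growing the side chain on compound 2

This account rests on a few compounds, and the source may have more. Where it says the series, first, only, none or still open, it means among the compounds named here.

Compound 1 `COc1cc(OC)c(/C=C/S(=O)(=O)Nc2ccc(OC)c(N)c2)c(OC)c1` gives 5 nM
Compound 2 `COC(=O)C(C)Nc1cc(NS(=O)(=O)/C=C/c2c(OC)cc(OC)cc2OC)ccc1OC` gives 100 nM

For the measured compounds named here, in a functional assay on DU-145 cells (Homo sapiens) for cytotoxicity, read by trypan blue exclusion, with a stated time of 96 h (on this read-out lower numbers stand for stronger inhibition and higher numbers for weaker inhibition), compound 2 gives 100 nM, the higher and therefore weaker of the two numbers so far. Compound 3 `COC(=O)C(Nc1cc(NS(=O)(=O)/C=C/c2c(OC)cc(OC)cc2OC)ccc1OC)c1ccc(F)cc1` has not yet been measured. It keeps the side chain of compound 2 but changes one group: 4-fluorophenyl in place of methyl on a saturated chain carbon bound to a carbonyl carbon and a nitrogen on an aromatic ring. Put simply, 4-fluorophenyl stands in place of methyl on a saturated chain carbon bound to a carbonyl carbon and a nitrogen on an aromatic ring.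

Going by the values given here, only one measured step bears on this change, and only indirectly: a 20-fold higher number from compound 1 to compound 2 (1.30 log units; beyond the scatter). That large step came from adding the 1-(methoxycarbonyl)ethyl group, which is the group now being altered. Among the compounds with values here, no measured pair shows what replacing its methyl does. The data therefore give no firm direction, so no step beyond the scatter is expected in this assay, with a slight lean towards a higher number and a wide margin on both sides. The estimated step is a 1.5-fold higher number from compound 2 to compound 3 (0.18 log units; within the scatter). Compound 3 is expected at 150 nM, with an estimated range from 30 nM to 800 nM.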

Compound 3, half-maximal inhibitory concentration: 2500 nM
For compound 3 the middle estimate is 17-fold (1.22 log units) below the measured one, outside the stated range (above it).
By their numbers in this assay, from the lowest: compound 1; then compound 2; then compound 3.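

In this assay the saturated chain carbon bound to a carbonyl carbon and a nitrogen on an aromatic ring proves sensitive to what it carries: 4-fluorophenyl in place of methyl gives a 25-fold higher number from compound 2 to compound 3 (1.40 log units; beyond the scatter) and so moves the number well beyond the scatter. This is a second large rise in the same direction, after a 20-fold higher number from compound 1 to compound 2 (1.30 log units; beyond the scatter) for 1-(methoxycarbonyl)ethyl in place of hydrogen, and the whole (4-fluorophenyl)(methoxycarbonyl)methyl group in place of that hydrogen amounts to a 500-fold higher number from compound 1 to compound 3 (2.70 log units; beyond the scatter) in total, so across these three compounds the number rises as the group on this nitrogen grows, with none going against that trend. No measurement shown here explains these rises.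

The compounds shown do not separate the effect of the aromatic ring from that of its fluorine, and a plain phenyl or a short chain such as ethyl at the same carbon would speak to that. They also leave open what the methoxycarbonyl group contributes, as a carboxylic acid or an amide in its place, or a simple methyl on the nitrogen, could read quite differently.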